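A few compounds are considered here, and "the series" means these few. Any claim that something is new, unique, unknown or untested is made for them only; others in the source may bear on it.

Working notes on the series.

Compound 1 `CN(c1ncco1)c1cnc(NCc2c(F)ccc3c2CCO3)n2cnnc12` is the reference point here. In an ADME assay on microsomes from liver (Homo sapiens) for metabolic stability, read by LC-MS, using NADPH, with stated times of 5 min and 30 min, tested at 1 uM (on this read-out lower numbers stand for slow clearance and higher numbers for fast clearance), compound 1 gives 11 mL.min-1.g-1. Compound 2 `Cc1ncccc1-c1cnc(NCc2c(F)ccc3c2CCO3)c2ncc(=O)[nH]c12` gives 21 mL.min-1.g-1 in this assay, and compound 3 `CN(C)C(=O)c1cc(-c2cnc(NCc3c(F)ccc4c3CCO4)c3cn[nH]c(=O)c23)n(C)n1` gives 21 mL.min-1.g-1 in this assay; both of these numbers lie within the usual scatter of the number for compound 1, so the three compounds cannot be told apart on this read-out, even though compound 1 carries the lowest of the three figures as written.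

Compound 4 `Fc1ccc2c(c1CNc1ncc(Nc3ccccc3)c3nncn13)CCO2` has not yet been measured in this assay. Relative to compound 1 the change is anilino in place of methyl(1,3-oxazol-2-yl)amino on an aromatic carbon. Going by the values given here, no pair of measured compounds differs in just one place, so there is no measured step to lean on; the expectation for compound 4 rests only on the three numbers above and on the nature of the change.

The step from compound 1 to compound 4 in this assay is expected to be a 2.0-fold higher number from compound 1 to compound 4 (0.30 log units; within the scatter), a rise of modest size, at or a little beyond the edge of the scatter. For compound 4 the estimated value in this assay is 22 mL.min-1.g-1, with a likely range from 9 mL.min-1.g-1 to 50 mL.min-1.g-1.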

Compound 4, intrinsic clearance in microsomes: 20 mL.min-1.g-1
Beside the measured number, compound 4's estimate is 1.1-fold (0.04 log units) above it; measured number inside the range.
By their numbers in this assay, from the lowest: compounds 1, 4, 2 and 3 (each within the scatter of the next).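

This gives the series its first step that differs in one place. On the aromatic carbon of the six-membered aromatic ring with 2 nitrogen, anilino in place of methyl(1,3-oxazol-2-yl)amino gives a 1.8-fold higher number from compound 1 to compound 4 (0.26 log units; within the scatter) in this assay, so at this position the read-out does not separate the two groups. The swap replaces a five-membered aromatic ring with 2 hetero atoms by a six-membered aromatic ring of carbon only, and brings in 1 hydrogen-bond donor, yet this single step shows that these differences taken together leave the clearance number within the scatter, while no measurement at hand accounts for that outcome.

Going by these compounds, whether the same holds for a non-aromatic group at this carbon, such as dimethylamino or morpholino, or for an anilino carrying a fluorine or a methoxy on its ring, stays open. On these data alone, compounds 2 and 3 differ from compound 1 and compound 4 in more than one place, so what the core itself contributes to clearance also stays open.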